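Replacing the phenylcarbamoyl arm of compound 3

This account rests on a few compounds, and the source may have more. Where it says the series, first, only, none or still open, it means among the compounds named here.

Measured in a functional assay on U-937 cells (Homo sapiens) for antiproliferative activity, read by MTT assay, with a stated time of 24 h; on this read-out higher numbers stand for weaker inhibition and lower numbers for stronger inhibition:
- compound 1 `CCCCNC(=O)COc1ccc(C(=O)c2c(CCCC)oc3ccccc23)cc1`: 22800 nM
- compound 2 `CCCCc1oc2ccccc2c1C(=O)c1ccc(OCC(=O)N2CCOCC2)cc1`: 45400 nM
- compound 3 `CCCCc1oc2ccccc2c1C(=O)c1ccc(OCC(=O)Nc2ccccc2)cc1`: 25900 nM

Compound 3 holds the middle number of the three, yet it cannot be separated from either of the others: a 1.1-fold higher number from compound 1 to compound 3 (0.06 log units; within the scatter), and a 1.8-fold lower number from compound 2 to compound 3 (0.24 log units; within the scatter). The next compound is compound 4 `CCCCc1oc2ccccc2c1C(=O)c1ccc(OCCCC(=O)N2CCCCC2)cc1`, which carries the change (2-((piperidin-1-yl)carbonyl)ethyl in place of phenylcarbamoyl on a saturated chain carbon bound to an oxygen on an aromatic ring). In words, this is 2-((piperidin-1-yl)carbonyl)ethyl in place of phenylcarbamoyl on a saturated chain carbon bound to an oxygen on an aromatic ring.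

The nearest evidence concerns the group on the amide carbonyl. There, a 2.0-fold higher number from compound 1 to compound 2 (0.30 log units; within the scatter) also stays within the scatter. The morpholin-4-yl amide compound 2, at 45400 nM, is the closest measured match. Going by the values given here, no measured compound tests the longer chain, so that part of the change remains open. No step beyond the scatter is therefore expected in this assay. The expected step is a 1.2-fold higher number from compound 3 to compound 4 (0.09 log units; within the scatter). For compound 4 the estimated value is 32000 nM, with an expected range from 13000 nM to 70000 nM.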

Compound 4, half-maximal inhibitory concentration: 16600 nM
Beside the measured number, compound 4's estimate is 1.9-fold (0.29 log units) above it, within the range that was stated.
By their numbers in this assay, from the lowest: compounds 4, 1, 3 and 2 (each within the scatter of the next, the first and the last beyond it).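

In this assay, going by these compounds alone, this position accepts a wider change than the earlier compounds tested: 2-((piperidin-1-yl)carbonyl)ethyl replaces phenylcarbamoyl, trading the aromatic ring for a non-aromatic one and leaving 0 hydrogen-bond donors, with a 1.6-fold lower number from compound 3 to compound 4 (0.19 log units; within the scatter) and, against butylcarbamoyl, a 1.4-fold lower number from compound 1 to compound 4 (0.14 log units; within the scatter). Within the data shown here, the only step beyond the scatter so far comes against the (morpholin-4-yl)carbonyl arm, a 2.7-fold lower number from compound 2 to compound 4 (0.44 log units; beyond the scatter), though it is modest and combines a different amide ring with a longer chain, so neither part can be credited alone. No supporting measurement bears on this step.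

A piperidin-1-yl amide on the shorter chain and a morpholin-4-yl amide on the longer chain would separate those two parts. Going by these compounds, whether a carboxylic acid or a free amine at the end of the chain fits this position also remains open.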